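Methylating a Phenol on a Pyrazole Chalcone Scaffold

The source may hold more compounds than are shown below. What is called first, only, known or untested is meant among the compounds shown, and "the series" means these compounds.

Of the compounds shown here, two built on the same core have been measured in a functional assay on HT-29 cells (Homo sapiens) for antiproliferative activity, read by MTT assay, with a stated time of 48 h; on this read-out lower numbers stand for stronger inhibition and higher numbers for weaker inhibition. Compound 1, `COc1ccc(N/C=C\C(=O)c2cn(-c3ccccc3)nc2-c2ccc(Cl)cc2)cc1`, gives 8930 nM in this assay. Compound 2, `COc1ccc(-c2nn(-c3ccccc3)cc2C(=O)/C=C\Nc2ccc(O)cc2)cc1`, gives 2460 nM, the lower of the two numbers, and the gap between compound 2 and compound 1 lies beyond the usual scatter of repeated runs. Compound 1 and compound 2 differ in two places, so no single step can be read from that pair.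

Compound 3, `COc1ccc(N/C=C\C(=O)c2cn(-c3ccccc3)nc2-c2ccc(OC)cc2)cc1`, has not yet been measured. It is reached from compound 2 by one change: methyl in place of hydrogen on an oxygen on an aromatic ring. Within the data shown here, since no measured pair shows this change on its own, any expectation rests on loose footing. A modest move toward weaker inhibition, or none beyond the scatter, is expected. Compound 3 is therefore estimated at 4000 nM in this assay, within a range from 1500 nM to 12000 nM, which means an expected step of a 1.6-fold higher number from compound 2 to compound 3 (0.21 log units; within the scatter).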

Compound 3, half-maximal inhibitory concentration: 8760 nM
The estimate for compound 3 lay 2.2-fold (0.34 log units) below the measured number, within the range that was stated.
By their numbers in this assay, from the lowest: compound 2; then compounds 3 and 1 (each within the scatter of the next).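

In this assay, among these compounds, methyl in place of hydrogen on the oxygen of the 4-hydroxyphenyl group gives a 3.6-fold higher number from compound 2 to compound 3 (0.55 log units; beyond the scatter) and so shows this change on its own for the first time. Among the compounds shown here, compound 3 also separates the second difference between compound 1 and compound 2: methoxy in place of chloro on an aromatic carbon gives a 1.0-fold lower number from compound 1 to compound 3 (0.01 log units; within the scatter) and thus, of these two changes, only the one at the oxygen lies beyond the scatter. No measurement shown here explains why the hydroxy and methoxy compounds differ.

From the compounds shown here alone, whether the step at the oxygen would hold with chloro in place of methoxy on the other aromatic ring remains open. So does how an amine or a carboxylic acid in place of the hydroxy group would read.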